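Hydroxamate chain length on a shared core

The source may hold more compounds than are shown below. What is called first, only, known or untested is meant among the compounds shown, and "the series" means these compounds.

Compound 1 `Nc1ncnc2c1c(-c1cnc3[nH]ccc3c1)nn2CCCCCC(=O)NO` gives only a limit in a functional assay on MCF7 cells (Homo sapiens) for inhibition, read by MTT assay, with a stated time of 72 h (a lower number here means a stronger inhibitor, a higher number a weaker inhibitor), > 150000 nM.
Compound 2 `Nc1ncnc2c1c(-c1cnc3[nH]ccc3c1)nn2CCCCCCCCCC(=O)NO` gives 23200 nM.
Compound 3 `Nc1ncnc2c1c(-c1cnc3[nH]ccc3c1)nn2CCCCCCC(=O)NO` gives 19800 nM.

The values of compound 2 and compound 3 lie within the scatter of each other, a 1.2-fold lower number from compound 2 to compound 3 (0.07 log units; within the scatter), and their cores differ by hydroxycarbamoyl in place of 3-(hydroxycarbamoyl)propyl on a saturated chain carbon, six bonds along the chain from an aromatic nitrogen. The step of an at least 6.4-fold higher number from compound 2 to compound 1 (0.81 log units; beyond the scatter) is the change (hydroxycarbamoyl in place of 4-(hydroxycarbamoyl)butyl on a saturated chain carbon, five bonds along the chain from an aromatic nitrogen), and it ends at the limit (the limit of > 150000 nM in this assay, at which 1 of the 3 values shown sits). The step of an at least 7.5-fold lower number from compound 1 to compound 3 (0.87 log units; beyond the scatter) runs the other way.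

Compound 4 `Nc1ncnc2c1c(-c1cnc3[nH]ccc3c1)nn2CCC(=O)NO` is not yet measured. From compound 3 it takes the same kind of change, (hydroxycarbamoyl in place of 4-(hydroxycarbamoyl)butyl on a saturated chain carbon, two bonds along the chain from an aromatic nitrogen), the place being two bonds rather than five bonds along the chain from the aromatic nitrogen. The expected step is a 15-fold higher number from compound 3 to compound 4 (1.18 log units; beyond the scatter), because the step of an at least 6.4-fold higher number from compound 2 to compound 1 (0.81 log units; beyond the scatter) already ends at a limit. Compound 4 is therefore estimated at 300000 nM. The expected range for compound 4 runs from 100000 nM to 1000000 nM. A limit rather than a number is the likely report.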

Compound 4, half-maximal inhibitory concentration: > 150000 nM
Compound 4 was reported as a limit (the forecaster's own chance of this, stated with the estimate: 80%); the middle value is on the limit's open side.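

In this assay, hydroxycarbamoyl in place of 4-(hydroxycarbamoyl)butyl gives an at least 7.5-fold higher number from compound 3 to compound 4 (0.87 log units; beyond the scatter), so the change points the same way at both places in the chain: the same change on two cores in this assay, an at least 6.4-fold higher number (0.81 log units; beyond the scatter) from compound 2 to compound 1 and an at least 7.5-fold higher number (0.87 log units; beyond the scatter) from compound 3 to compound 4; the limit leaves it open whether they differ

Compound 4 gives only a limit, > 150000 nM.

This shows that the direction carries from one core to the other, but not that the size does, and the step between compound 1 and compound 4 cannot be read, as both ends are limits: the limit of > 150000 nM in this assay, at which 2 of the 4 values shown sit.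

The compounds shown leave open whether a longer chain than that of compound 2 keeps a measurable value. They also leave open whether a carboxylic acid in place of the hydroxycarbamoyl end follows the same course on these chains.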